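The source may report more compounds than this note shows. Statements on the series, on what has been measured and on what is new or still open speak of the compounds shown alone.

- Compound 1 `Cc1nc(C#N)c(N)c2c1C(=O)N(Cc1ccccc1)C2=O`: "not determined" (no result reported)
- Compound 2 `Cc1nc(C(=O)OC2CC2)c(N)c2c1C(=O)N(Cc1ccccc1)C2=O`: "not determined" (no result reported)
- Compound 3 `Cc1noc(-c2nc(C)c3c(c2N)C(=O)N(Cc2ccccc2)C3=O)n1`: > 100000 nM

In an ADME assay on Vero cells (Chlorocebus sabaeus) for cytotoxicity, read by MTT assay (on this read-out higher numbers stand for weaker inhibition and lower numbers for stronger inhibition), compound 3 gives > 100000 nM, and this is a limit of the assay, not a number. For the measured compounds named here, it is the only reading, as neither compound 1 nor compound 2 has a result. Compound 4 `Cc1nc(-c2nc(C(F)(F)F)no2)c(N)c2c1C(=O)N(Cc1ccccc1)C2=O` differs from compound 3 by carrying trifluoromethyl in place of methyl on an aromatic carbon. Going by the values given here, no measured pair of compounds shows what such a change does here, so this expectation rests on the limit of compound 3 alone. The expected a number no higher from compound 3 to compound 4 (the limit leaves the size open) in this assay is none beyond the scatter. Compound 4 is estimated at 100000 nM, with an expected range from 30000 nM to 200000 nM.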

Compound 4, half-maximal inhibitory concentration: > 100000 nM
Compound 4 ended at the assay's limit; the forecaster's own chance of this, stated with the estimate: 70%; the middle value sits exactly at the limit.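

In this assay no step can be read from compound 3 to compound 4, as both stand at a limit and not at a number: the limit of > 100000 nM in this assay, at which 2 of the 4 values shown sit. The compounds shown leave open what trifluoromethyl in place of methyl does on this read-out.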